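The source may hold more compounds than are shown below. What is called first, only, known or untested is meant among the compounds shown, and "the series" means these compounds.

Measured so far in an ADME assay on the whole organism (plasma, Mus musculus, strain CD1), read by LC-MS, with a stated time of 24 h; a lower number here means a smaller unbound share, a higher number a larger unbound share of the compound

Compound 1 `O=C(O)Cn1nc(Cc2nc3cc(F)c(OCC4CC4)cc3[nH]2)c2ccccc2c1=O` gives 0.026
Compound 2 `O=C(O)Cn1nc(Cc2cn3cc(OCC4CC4)c(Cl)cc3n2)c2ccccc2c1=O` gives 0.013
Compound 3 `O=C(O)Cn1nc(Cn2cc3cc(OCC4CC4)c(Cl)cc3n2)c2ccccc2c1=O` gives 0.01

All three numbers are small fractions, so in each case only a minor share of the compound is free rather than bound. Compound 3 cannot be told apart from compound 2 within the usual scatter of this assay, while compound 1 stands higher than compound 3 by more than that scatter.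

The next compound, compound 4 `C[C@H](C(=O)O)n1nc(Cn2cc3cc(OCC4CC4)c(Cl)cc3n2)c2ccccc2c1=O`, keeps all of compound 3 except for one small change, (methyl in place of hydrogen on a saturated chain carbon bound to an aromatic nitrogen and a carbonyl carbon), which is methyl in place of hydrogen on a saturated chain carbon bound to an aromatic nitrogen and a carbonyl carbon. Carboxymethyl thus becomes 1-carboxyethyl.

Within the data shown here, no two measured compounds differ in only one place, so the data offer no direct precedent for this change. The starting point is compound 3 (0.01), and one added carbon is a modest alteration. The expected step of a 1.3-fold lower number from compound 3 to compound 4 (0.10 log units; within the scatter) is small and downward, and stays within the scatter. For compound 4 the estimated value is 0.008, with an expected range from 0.004 to 0.016.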

Compound 4, unbound fraction: 0.011
The estimate for compound 4 lay 1.4-fold (0.14 log units) below the measured number; the measured number falls inside the stated range.
By their numbers in this assay, from the lowest: compounds 3, 4, 2 and 1 (each within the scatter of the next, the first and the last beyond it).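

In this assay, among these compounds, this pair gives the first direct reading of a single change: a 1.1-fold higher number from compound 3 to compound 4 (0.04 log units; within the scatter). Methyl in place of hydrogen on a saturated chain carbon bound to an aromatic nitrogen and a carbonyl carbon therefore leaves the unbound fraction indistinguishable from that of the parent, so carboxymethyl and 1-carboxyethyl cannot be told apart in this measurement, and at this position on this core, the added carbon shifts the free share of compound by no more than repeat measurements would. No supporting data bear on why the number holds steady, so the result stands as an observation without an explanation.

Still open, as far as these compounds go, is whether a larger group on the same carbon, such as an ethyl or a second methyl, or the opposite spatial arrangement of the methyl, would also leave the unbound fraction unchanged. Among the compounds shown here, it is equally open whether the same swap would behave this way on the cores of compound 1 and compound 2, since the change has been read on only one core.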